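The source may report more compounds than this note shows. Statements on the series, on what has been measured and on what is new or still open speak of the compounds shown alone.

Measured compounds:

Compound 1 `Nc1cccc(-c2cn(CC(=O)Nc3nccs3)nn2)c1` — 1270 nM
Compound 2 `Cc1cc(NC(=O)Cn2cc(-c3ccc(C#N)cc3)nn2)no1` — 9320 nM

Both compounds were tested in a functional assay on BMDM cells (Mus musculus, strain C57BL/6) for inhibition, with a stated time of 2 days; a higher number here means a weaker inhibitor, a lower number a stronger inhibitor. Of the two numbers, compound 2 has the higher one: it is the weaker inhibitor, and its gap to compound 1 lies beyond the usual scatter of this assay. The two compounds differ in more than one place, so the comparison between them says nothing about any single change.

Compound 3 `C#Cc1ccc(-c2cn(CC(=O)Nc3cc(C)on3)nn2)cc1` has not yet been measured in this assay. It is built like compound 2, with one change: ethynyl in place of cyano on an aromatic carbon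

Within the data shown here, no pair of measured compounds shows what this change does here. With nothing to go on but the two numbers above, the expected step from compound 2 to compound 3 is small, in no clear direction, and likely within the scatter: a 1.0-fold lower number from compound 2 to compound 3 (0.02 log units; within the scatter). Compound 3 is therefore estimated at 9000 nM in this assay, within a range of 3000 nM to 30000 nM.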

Compound 3, half-maximal inhibitory concentration: > 30000 nM
Compound 3: no number, only a limit; the forecaster's own chance of this, stated with the estimate: 10%; middle value at least 3.3-fold (0.52 log units) from the limit.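

In this assay, among these compounds, this is the first comparison that changes one place only, and putting ethynyl in place of cyano on the aromatic carbon para to a large group gives an at least 3.2-fold higher number from compound 2 to compound 3 (0.50 log units; beyond the scatter). Compound 3 has only a limit of the assay, not a number: the limit of > 30000 nM in this assay, at which 1 of the 3 values shown sits. Cyano and ethynyl have the same count of heavy atoms and each holds a triple bond, yet this single swap, which takes away a nitrogen and a hydrogen-bond acceptor, is enough to leave the cyano compound as the stronger inhibitor of the pair.

Going by these compounds, it remains open how a carboxylic acid or a methoxy group would fare at this same place with the rest of compound 2 kept. Compound 1 differs from compound 2 in more than one place and gives no answer.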